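Working notes: fluoro in place of hydrogen on compound 1

A few compounds are considered here, and "the series" means these few. Any claim that something is new, unique, unknown or untested is made for them only; others in the source may bear on it.

Compound 1 `c1ccc(-c2ccc(-c3ccc(-c4nc5ccccc5[nH]4)cc3)cc2)cc1`: 39700 nM
Compound 2 `Cc1ccc2[nH]c(-c3ccc(-c4ccc(-c5ccc(N(C)C)cc5)cc4)cc3)nc2c1`: 6240 nM
Compound 3 `Cc1ccc2[nH]c(-c3ccc(-c4ccc(-c5cccc(Cl)c5)cc4)cc3)nc2c1`: 2260 nM

All three values come from a functional assay on KB cells (Homo sapiens) for inhibition, read by sulforhodamine B assay; on this read-out lower numbers stand for stronger inhibition of growth and higher numbers for weaker inhibition of growth. Compound 1 stands highest of the three, and compound 2 and compound 3 both lie lower by more than the scatter. Both also differ from compound 1 in more than one place, so their gaps to compound 1 cannot be assigned to any single group.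

The next compound is compound 4 `Fc1ccc(-c2ccc(-c3ccc(-c4nc5ccccc5[nH]4)cc3)cc2)cc1`, and the change from compound 1 is fluoro in place of hydrogen on an aromatic carbon. This is fluoro in place of hydrogen on an aromatic carbon, para to a large group.

Among the measured compounds shown here, no measured step shows this exchange. For the measured compounds named here, the only step between close neighbours is a 2.8-fold lower number from compound 2 to compound 3 (0.44 log units; beyond the scatter), where 3-chlorophenyl takes the place of 4-(dimethylamino)phenyl. That step is modest but beyond the scatter, and it bears only loosely on a hydrogen-to-fluoro change. A modest step to a lower number in this assay is therefore expected, though a step within the scatter remains possible.

For compound 4 the estimated value is 18000 nM, with an expected range of 6000 nM to 45000 nM. The expected change is a 2.2-fold lower number from compound 1 to compound 4 (0.34 log units; beyond the scatter).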

Compound 4, concentration for 50% growth inhibition: 41300 nM
Compound 4: middle estimate off by 2.3-fold (0.36 log units), on the low side, and the stated range covers the measured number.
By their numbers in this assay, from the lowest: compound 3; then compound 2; then compounds 1 and 4 (each within the scatter of the next).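

In this assay, among the compounds shown here, phenyl to 4-fluorophenyl on the core of compound 1 gives a 1.0-fold higher number from compound 1 to compound 4 (0.02 log units; within the scatter), the first reading of a single-atom exchange at this place, on an aromatic carbon para to a large group. For the compounds shown here, the only earlier step, a 2.8-fold lower number from compound 2 to compound 3 (0.44 log units; beyond the scatter), exchanged one whole substituted phenyl group for another and could not show what fluoro in place of hydrogen does alone. On this core, at this position, fluoro and hydrogen cannot be told apart on this read-out, and no other measurement bears on the result.

Going by these compounds, whether a different group at this same place, such as methoxy, a primary amine or a carboxylic acid, would move the number beyond the scatter remains open. Also open, on these data alone, are whether fluoro in place of hydrogen reads the same on the cores of compound 2 and compound 3, and which of the several differences separating those two compounds from compound 1 accounts for their lower numbers.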